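Benzofuran for thiophene on the shared nucleoside core

This account rests on a few compounds, and the source may have more. Where it says the series, first, only, none or still open, it means among the compounds named here.

Measured so far:
compound 1 `O=c1[nH]cnc2c1c(-c1cccs1)cn2[C@@H]1O[C@H](CO)[C@@H](O)[C@H]1O`: > 20000 nM
compound 2 `C#Cc1cn([C@@H]2O[C@H](CO)[C@@H](O)[C@H]2O)c2ncnc(NC)c12`: 1380 nM
compound 3 `Nc1nc2c(c(-c3cccs3)cn2[C@@H]2O[C@H](CO)[C@@H](O)[C@H]2O)c(=O)[nH]1`: 16800 nM

In a functional assay on K562 cells (Homo sapiens), read by MTT assay, with a stated time of 72 h (a lower number here means a stronger inhibitor, a higher number a weaker inhibitor), compound 1 gives only a limit, > 20000 nM, not a number. Compound 1 therefore stands at the limit of > 20000 nM in this assay, at which 1 of the 3 values shown sits. Within the data shown here, compound 3, in this assay, gives 16800 nM; the single step available is an at least 1.1-fold lower number from compound 1 to compound 3 (0.07 log units; that floor lies within the scatter). Among the measured compounds shown here, compound 2 gives 1380 nM on a differently substituted core, with no one-place step to compound 1.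

Compound 4 `O=c1[nH]cnc2c1c(-c1cc3ccccc3o1)cn2[C@@H]1O[C@H](CO)[C@@H](O)[C@H]1O` differs from compound 1 by 1-benzofuran-2-yl in place of thiophen-2-yl on an aromatic carbon. For the measured compounds named here, no measured step exchanges the thiophen-2-yl group, so no step bears directly on this change; the one step present concerns an amino group elsewhere. Compound 4 is expected to remain near compound 1, the expected step being an at least 1.3-fold lower number from compound 1 to compound 4 (0.12 log units; that floor lies within the scatter). The estimate for compound 4 is 15000 nM, with a range from 3000 nM to 60000 nM.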

Compound 4, half-maximal inhibitory concentration: > 20000 nM
Compound 4: a limit, no number (the forecaster's own chance of this, stated with the estimate: 50%); middle value at least 1.3-fold (0.12 log units) away from the limit.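

In this assay compound 1 and compound 4 both give only a limit, so the step between them cannot be read: the limit of > 20000 nM in this assay, at which 2 of the 4 values shown sit.

Left open is how 1-benzofuran-2-yl and thiophen-2-yl compare on the shared core.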